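Dropping One Methoxy Group from Compound 2

The compounds below may be only part of what the source reports. "The series", "measured", "known", "first", "only" and "open" are said of these compounds alone.

Of the compounds shown here, two built on the shared core have so far been measured in a functional assay on IGROV-1 cells (Homo sapiens) for inhibition, read by sulforhodamine B assay, with a stated time of 48 h; a higher number here means a weaker inhibitor of growth, a lower number a stronger inhibitor of growth. Compound 1 `COc1ccc(-c2cc(/C=C/C(=O)c3ccc(N)cc3)[nH]n2)cc1` gives 2270 nM. Compound 2 `COc1cc(-c2cc(/C=C/C(=O)c3ccc(N)cc3)[nH]n2)cc(OC)c1OC` gives 3200 nM, the higher of the two numbers, though the gap to compound 1 lies within the usual scatter of this assay, so the two cannot be told apart. Compound 3 `COc1ccc(-c2cc(/C=C/C(=O)c3ccc(N)cc3)[nH]n2)cc1OC` has not yet been measured. It differs from compound 2 in one place: hydrogen in place of methoxy on an aromatic carbon. Among the measured compounds shown here, no step between measured compounds exists that would show what such a change does here, so only a guess can be offered. The step from compound 2 to compound 3 is expected to be small, a 1.2-fold lower number from compound 2 to compound 3 (0.09 log units; within the scatter), toward a somewhat lower number but not beyond the scatter. Compound 3 is thus estimated to give 2600 nM in this assay, within a range from 1300 nM to 5500 nM.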

Compound 3, concentration for 50% growth inhibition: 4560 nM
Compound 3: middle estimate off by 1.8-fold (0.24 log units), on the low side; the measured number falls inside the stated range.
By their numbers in this assay, from the lowest: compounds 1, 2 and 3 (each within the scatter of the next).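

With compound 3, the methoxy group on this aromatic carbon can now be read from both sides in this assay: taking it away gives a 1.4-fold higher number from compound 2 to compound 3 (0.15 log units; within the scatter), while putting one on the lighter compound gives a 2.0-fold higher number from compound 1 to compound 3 (0.30 log units; within the scatter). Both steps lie within the scatter, so among these compounds neither the loss nor the gain of this methoxy group is shown to shift the growth-inhibition number, and the steps give no sign of a trend with the count of methoxy groups. Nothing at hand bears on the reason for these results.

Still open, from the compounds shown here alone, is whether a different group on this aromatic carbon, such as a hydroxyl, a fluorine or an amine, would give a step beyond the scatter. Also open, going by these compounds, is what a change away from this ring would do, for instance a carboxylic acid in place of the amine on the shared core.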